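The compounds below may be only part of what the source reports. "The series", "measured", "known", "first", "only" and "open" are said of these compounds alone.

Compound 1 `Cc1ccc(S(=O)(=O)N2CC[C@@H](Cl)C[C@@H]2C2CCCCC2)cc1` and compound 2 `Cc1ccc(S(=O)(=O)N2CC[C@@H](Cl)C[C@@H]2c2ccccc2)cc1` share one core; in a functional assay on A2780 cells (Homo sapiens) for antiproliferative activity, read by sulforhodamine B assay, with a stated time of 48 h (a higher number here means a weaker inhibitor of growth, a lower number a stronger inhibitor of growth), compound 1 gives 72000 nM. For compound 2 the assay reports only a limit, > 100000 nM. The change between them is phenyl in place of cyclohexyl on a saturated ring carbon, and the step amounts to an at least 1.3-fold higher number from compound 1 to compound 2 (0.14 log units; that floor lies within the scatter). Compound 3 `Cc1ccc(S(=O)(=O)N2CCC(Br)=CC2C2CCCCC2)cc1` rests on another core, and the difference between the two cores is not broken down here; in this assay compound 3 gives 44000 nM. Compound 4 `Cc1ccc(S(=O)(=O)N2CCC(Br)=CC2c2ccccc2)cc1` awaits measurement and differs from compound 3 by phenyl in place of cyclohexyl on a saturated ring carbon. The surroundings differ: one place lies two ring bonds from the ring atom that bears a chloro group, the other two ring bonds from the ring atom that bears a bromo group, which makes this the same kind of change, not the same. Given that compound 2 reached the limit of > 100000 nM in this assay, at which 1 of the 3 values shown sits, and the step of an at least 1.3-fold higher number from compound 1 to compound 2 (0.14 log units; that floor lies within the scatter), the expected step is a 2.0-fold higher number from compound 3 to compound 4 (0.31 log units; beyond the scatter). Compound 4 is estimated at 90000 nM in this assay.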

Compound 4, concentration for 50% growth inhibition: 49000 nM
Beside the measured number, compound 4's estimate is 1.8-fold (0.26 log units) above it; the measured number falls inside the stated range.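

In this assay, phenyl in place of cyclohexyl gives a 1.1-fold higher number from compound 3 to compound 4 (0.05 log units; within the scatter), so on this core the change has no effect that stands clear of the scatter. Set beside the core of compound 1, the comparison stays unsettled: the same change on two cores in this assay, an at least 1.3-fold higher number (0.14 log units; that floor lies within the scatter) from compound 1 to compound 2 and a 1.1-fold higher number (0.05 log units; within the scatter) from compound 3 to compound 4; the limit leaves it open whether they differ. The value of compound 2 is a limit, so the data show neither that the change carries over unaltered from one core to the other nor that it depends on the core: the limit of > 100000 nM in this assay, at which 1 of the 4 values shown sits.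

The compounds shown leave open how a benzyl group or a longer alkyl chain would behave in place of phenyl or cyclohexyl. Also open, on these data alone, is how the change would read on a core bearing a fluoro group instead of the chloro or bromo group.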